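The compounds below may be only part of what the source reports. "The series", "measured", "known", "first", "only" and "open" are said of these compounds alone.

Working notes on the series in a functional assay on DU-145 cells (Homo sapiens) for antiproliferative activity, read by MTT assay, with a stated time of 72 h; a higher number here means a weaker inhibitor, a lower number a stronger inhibitor.

Compound 1, `O=C(COc1ccc(C(=O)/C=C/c2cccc(Br)c2)cc1)N[C@H]1CCOC1=O`, gives 9800 nM in this assay. Among the compounds with values here, that is the only number in hand: the other two readings are limits, and compound 1 therefore stands alone rather than at any rank. Compound 2, `O=C(CNc1ccc(Cl)cc1Cl)N[C@H]1CCOC1=O`, returns only a limit of > 64000 nM in this assay. Compound 3, `O=C1OCC[C@@H]1NC(=S)SCCOc1ccccc1Cc1ccccc1`, likewise returns only a limit of > 64000 nM in this assay. Both sit at the limit of > 64000 nM in this assay, at which 2 of the 3 values shown sit, which marks the ceiling of the measurement and not a value.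

Compound 4, `O=C(COc1ccc(C(=O)/C=C/c2ccc(F)c(F)c2)cc1)N[C@H]1CCOC1=O`, keeps the core of compound 1 and differs from it in one place: 3,4-difluorophenyl in place of 3-bromophenyl on a double-bonded chain carbon bound to a double-bonded chain carbon. Within the data shown here, no measured pair in this set shows the effect of such a swap, so the step from compound 1 cannot be anchored to an observed one. The expectation is a step from compound 1 to compound 4 of a 1.4-fold higher number from compound 1 to compound 4 (0.15 log units; within the scatter), within the usual scatter of repeated measurements. For compound 4 the estimate in this assay is 14000 nM, with a range from 5000 nM to 45000 nM.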

Compound 4, half-maximal inhibitory concentration: 19800 nM
For compound 4 the middle estimate is 1.4-fold (0.15 log units) below the measured one, within the range that was stated.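

Within the data shown here, this is the first measured one-place step: on a double-bonded chain carbon bound to a double-bonded chain carbon, 3,4-difluorophenyl in place of 3-bromophenyl gives a 2.0-fold higher number from compound 1 to compound 4 (0.31 log units; beyond the scatter) in this assay. The number at this position therefore responds to the change of aryl group, though modestly, and compound 4 still gives a number rather than a limit. Nothing in hand bears on the cause of this step.

A single swap cannot separate the loss of the bromine from the entry of the two fluorines. Also open, as far as these compounds go, is how the number would move with a phenyl carrying an amine or a carboxylic acid in this place, or with the unsubstituted phenyl.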